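A further methoxy on compound 2

The source may hold more compounds than are shown below. What is called first, only, known or untested is meant among the compounds shown, and "the series" means these compounds.

Measured in a functional assay on KBVIN cells (Homo sapiens) for cytotoxicity, read by sulforhodamine B assay, with a stated time of 72 h; a higher number here means that more compound is needed for the effect, a lower number that less compound is needed:
compound 1 `Cc1coc2cc(-c3ccc(O)c(O)c3)oc(=O)c12`: 23.3 uM
compound 2 `COc1cc(OC)cc(-c2cc3occ(C)c3c(=O)o2)c1`: > 69.9 uM (a limit, not a number)

Compound 1 gives a true number in this assay. Compound 2 stands at > 69.9 uM, which is a limit of the assay and not a number. Compound 3 `COc1cc(-c2cc3occ(C)c3c(=O)o2)cc(OC)c1OC` keeps the core of compound 2 and differs in one place: methoxy in place of hydrogen on an aromatic carbon. Here methoxy stands in place of hydrogen on an aromatic carbon, ortho to two methoxy groups. Among the compounds with values here, no measured pair shows what such a change does. Within the data shown here, the limit of compound 2 at > 69.9 uM is therefore the only guide, and no step beyond the usual scatter is expected in this assay. The expected change is an at least 1.0-fold lower number from compound 2 to compound 3 (0.03 log units; that floor lies within the scatter), and this estimate may turn out to be only another limit. For compound 3 the estimated value is 65 uM, with an expected range from 30 uM to 100 uM.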

Compound 3, concentration for half-maximal effect: > 63.3 uM
Compound 3: no number, only a limit; the forecaster's own chance of this, stated with the estimate: 65%; the middle value is on the limit's open side.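

Compound 2 and compound 3 each give only a limit in this assay, not a number, so the step between them cannot be read. The compounds shown leave open whether methoxy in place of hydrogen changes the concentration needed for the effect.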